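Thiophene Attachment Shift in a Leukemia Growth Assay

This account rests on a few compounds, and the source may have more. Where it says the series, first, only, none or still open, it means among the compounds named here.

Within the data shown here, compound 2 `N=C(N)N/N=C/c1c(-c2cccs2)nc2sccn12` is one of two compounds measured so far. In a functional assay on cells (Leukemia cell, Homo sapiens) for inhibition (on this read-out higher numbers stand for weaker inhibition of growth and lower numbers for stronger inhibition of growth), compound 2 gives 38000 nM, the lowest of the two numbers on hand, while compound 1 `N=C(N)N/N=C/c1c(-c2cccs2)nc2n1CCS2` gives 38900 nM in the same assay, a value that lies within the scatter of compound 2. Among the measured compounds shown here, no step between these two measured compounds is computed, and their numbers show only that the two sit at essentially the same level of growth inhibition.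

Compound 3 `N=C(N)N/N=C/c1c(-c2ccsc2)nc2sccn12` has yet to be measured. Its change from compound 2 is thiophen-3-yl in place of thiophen-2-yl on an aromatic carbon. Because compound 2 gives 38000 nM and no measured comparison points in any direction, the expected step of no change at the digits printed from compound 2 to compound 3 (within the scatter) is none beyond the scatter, in either direction. The estimate for compound 3 in this assay is 38000 nM, with a range from 15000 nM to 95000 nM.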

Compound 3, concentration for total growth inhibition: 24000 nM
Compound 3: middle estimate off by 1.6-fold (0.20 log units), on the high side; low and high end bracket the measured number.
By their numbers in this assay, from the lowest: compounds 3, 2 and 1 (each within the scatter of the next).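

Among these compounds, this is the first comparison at this position, on an aromatic carbon of the five-membered aromatic ring with 2 nitrogen, since compounds 1 and 2 carry the same thiophen-2-yl group and differ only in the core. With thiophen-3-yl in place of thiophen-2-yl, this assay shows a 1.6-fold lower number from compound 2 to compound 3 (0.20 log units; within the scatter), so the two attachments of the thiophene cannot be told apart in this read-out. Nothing measured on these compounds offers an explanation for this result.

The compounds shown leave open whether this position accepts anything other than a thiophene, such as a phenyl ring, a primary amine, a carboxylic acid or a longer alkyl chain. They also leave open whether thiophen-3-yl would give a similar number on the core of compound 1.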